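Swapping an Acrylamide Anilide for a Bromophenyl Anilide

This account rests on a few compounds, and the source may have more. Where it says the series, first, only, none or still open, it means among the compounds named here.

Compound 1 `O=C(CSc1nc(Nc2ccccc2)c2ccccc2n1)Nc1cccc(F)c1`: 12700 nM
Compound 2 `C=CC(=O)Nc1cccc(NC(=O)CSc2nc(Nc3ccccc3)c3ccccc3n2)c1`: 7310 nM

In a functional assay on MGC-803 cells (Homo sapiens) for inhibition, read by MTT assay, with a stated time of 72 h (on this read-out lower numbers stand for stronger inhibition and higher numbers for weaker inhibition), compound 2 gives the lowest of the two numbers, though the gap between them is only a 1.7-fold lower number from compound 1 to compound 2 (0.24 log units; within the scatter), which is within the scatter. Compound 3 `O=C(CSc1nc(Nc2ccccc2)c2ccccc2n1)Nc1ccc(Br)cc1` differs from compound 2 by 4-bromophenyl in place of 3-((vinylcarbonyl)amino)phenyl on an amide-type nitrogen. For the measured compounds named here, the one measured step, from a fluoro group to the (vinylcarbonyl)amino group, was small; compound 3 returns to a halogen-bearing ring, so its number is expected near compound 1 rather than lower. The step from compound 2 to compound 3 is estimated as a 1.6-fold higher number from compound 2 to compound 3 (0.22 log units; within the scatter). Compound 3 is thus expected to give 12000 nM, within 4000 nM to 35000 nM.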

Compound 3, half-maximal inhibitory concentration: 19300 nM
Estimate against measurement, compound 3: 1.6-fold (0.21 log units) below; low and high end bracket the measured number.
By their numbers in this assay, from the lowest: compounds 2, 1 and 3 (each within the scatter of the next, the first and the last beyond it).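

In this assay, for the compounds shown here, replacing the 3-((vinylcarbonyl)amino)phenyl group on the amide-type nitrogen with 4-bromophenyl gives the first step here that clears the scatter (a 2.6-fold higher number from compound 2 to compound 3 (0.42 log units; beyond the scatter)). Replacing 3-fluorophenyl with 4-bromophenyl at the same nitrogen stays within it (a 1.5-fold higher number from compound 1 to compound 3 (0.18 log units; within the scatter)), so these two halogen-bearing rings cannot be told apart. No measurement here explains either step.

The step from compound 2 to compound 3 changes both the substituent and its place on the ring, so their contributions cannot be separated. As far as these compounds go, how an amine or a carboxylic acid on this ring would read remains open.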